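A few compounds are considered here, and "the series" means these few. Any claim that something is new, unique, unknown or untested is made for them only; others in the source may bear on it.

Compound 1 `COc1cc(-c2nnc(SCc3cccc(Br)c3)o2)ccc1O`: 48100 nM
Compound 2 `COc1cc(-c2nnc(SCc3cccc(Cl)c3)o2)ccc1O`: 8290 nM

In a functional assay on cells (T-cell, Mus musculus, strain BALB/c) for inhibition, read by MTT assay, with stated times of 24 h and 72 h (a lower number here means a stronger inhibitor, a higher number a weaker inhibitor), compound 1 gives 48100 nM, the highest number of the two, while compound 2 gives 8290 nM. Among the compounds with values here, the single measured step, a 5.8-fold lower number from compound 1 to compound 2 (0.76 log units; beyond the scatter), is modest but beyond the scatter. Compound 3 `COc1cc(-c2nnc(SCc3ccccc3C)o2)ccc1O` differs from compound 1 thus: 2-methylphenyl in place of 3-bromophenyl on a saturated chain carbon bound to a sulfur. Within the data shown here, no measured step trades a halogen-bearing ring for a methyl-bearing one at this place, so the step from compound 1 to compound 2 bears on it only loosely, showing that this ring tolerates change. Compound 3 is therefore expected to give about 20000 nM, between 5000 nM and 80000 nM, an expected step of a 2.4-fold lower number from compound 1 to compound 3 (0.38 log units; beyond the scatter) with wide uncertainty.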

Compound 3, half-maximal inhibitory concentration: 8420 nM
For compound 3 the middle estimate is 2.4-fold (0.38 log units) above the measured one; the measured number falls inside the stated range.
By their numbers in this assay, from the lowest: compounds 2 and 3 (each within the scatter of the next); then compound 1.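

At this saturated chain carbon bound to a sulfur, this assay shows a 1.0-fold higher number from compound 2 to compound 3 (0.01 log units; within the scatter) when 2-methylphenyl replaces 3-chlorophenyl, and a 5.7-fold lower number from compound 1 to compound 3 (0.76 log units; beyond the scatter) when it replaces 3-bromophenyl. A ring carrying no halogen can therefore sit here and match compound 2, so a halogen on this ring is not required for that level of inhibition. Going by these compounds, whether a plain phenyl, an amine or a carboxylic acid on this ring, or a longer chain in place of the methyl, would hold that level remains open. Nothing available explains why compound 1 stands apart from the other two.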